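Trifluoromethoxy Gives Way to Trifluoromethyl on the Shared Core

The source may hold more compounds than are shown below. What is called first, only, known or untested is meant among the compounds shown, and "the series" means these compounds.

In a functional assay on HL-60 cells (Homo sapiens) for cytotoxicity, read by WST assay, with a stated time of 48 h (a higher number here means that more compound is needed for the effect, a lower number that less compound is needed), compound 1 (`O=C1OC[C@H](Cc2ccccc2)[C@H]1Cc1cccc(O)c1`) gives > 100000 nM as a limit of the assay and not a number. Among the compounds with values here, compound 2 (`O=C1OC[C@H](Cc2ccccc2)[C@H]1Cc1ccc(OC(F)(F)F)cc1`) gives 27000 nM and is the only compound so far with a measured number. Compound 3 (`O=C1OC[C@H](Cc2ccccc2)[C@H]1Cc1ccc(C(F)(F)F)cc1`) carries trifluoromethyl in place of trifluoromethoxy on an aromatic carbon. Within the data shown here, no measured step bears on this change. The expected step of a 1.1-fold higher number from compound 2 to compound 3 (0.05 log units; within the scatter) is small, with nothing beyond the scatter foreseen in this assay for it. Compound 3 is expected at 30000 nM with an estimated range from 12000 nM to 80000 nM in this assay here.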

Compound 3, half-maximal effective concentration: 22000 nM
Beside the measured number, compound 3's estimate is 1.4-fold (0.13 log units) above it; the range from low to high includes it.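

In this assay, within the data shown here, placing trifluoromethyl in place of trifluoromethoxy on the aromatic carbon para to a large group gives a 1.2-fold lower number from compound 2 to compound 3 (0.09 log units; within the scatter), the first measured step on the shared core. At this position, then, removing the oxygen of trifluoromethoxy leaves the read-out within the scatter. Compound 2 and compound 3 both give numbers, clear of the ceiling reached elsewhere among the compounds shown: the limit of > 100000 nM in this assay, at which 1 of the 3 values shown sits.

On these data alone, whether an amine, a carboxylic acid or a nitrile at this position would move the number beyond the scatter remains open.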